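The source may report more compounds than this note shows. Statements on the series, on what has been measured and on what is new or still open speak of the compounds shown alone.

Four compounds share one core, and they differ only in the group carried on an aromatic carbon of a six-membered aromatic ring with 1 nitrogen. Compound 1 `Cc1cccc(Nc2nc(-c3ccncc3C#CCCCO)cs2)c1` carries a chain that ends in an alcohol, compound 2 `Cc1cccc(Nc2nc(-c3ccncc3-c3ccncc3)cs2)c1` carries a further ring, compound 3 `CCc1cnccc1-c1csc(Nc2cccc(C)c2)n1` carries an ethyl group, and compound 4 `C#Cc1cnccc1-c1csc(Nc2cccc(C)c2)n1` carries an ethynyl group. All of them are judged in a functional assay on RCC4 cells (Homo sapiens) for inhibition, read by XTT assay, with a stated time of 4 days; on this read-out lower numbers stand for stronger inhibition and higher numbers for weaker inhibition. In this assay compound 1 gives 6300 nM; 1120 nM (2 entries), and the spread between its own repeats can be seen in the several entries of compound 1 in this assay, 6300 nM; 1120 nM (2 entries). Compound 2 gives 13800 nM; 13800 nM (2 entries). Going by the values given here, compound 3 gives 6310 nM, the only number it has in this assay, while two further entries for it were recorded without a single number. Among the compounds with values here, no two measured compounds differ in just one place, so no single step has been measured. Compound 4 is not yet measured; it differs from compound 3 by ethynyl in place of ethyl on an aromatic carbon. Compound 1, whose group also holds a triple bond, gave numbers close to that of compound 3 or somewhat lower, so only a modest change is expected. The step from compound 3 to compound 4 is expected to be a 1.6-fold lower number from compound 3 to compound 4 (0.20 log units; within the scatter). Compound 4 is therefore estimated at 4000 nM, with a likely range from 1000 nM to 15000 nM.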

Compound 4, half-maximal inhibitory concentration: 1380 nM
Estimate against measurement, compound 4: 2.9-fold (0.46 log units) above; low and high end bracket the measured number.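

In this assay, going by these compounds alone, this is the first change of a single group that can be read directly, and it gives a 4.6-fold lower number from compound 3 to compound 4 (0.66 log units; beyond the scatter). Ethyl and ethynyl have the same count of heavy atoms, and neither brings a ring, a hydrogen-bond donor or acceptor, or a net charge; the listed difference is the triple bond outside aromatic rings, so this position on the aromatic carbon, ortho to a large group, responds to a change that leaves all those counts the same. The size of the step still rests on a single number for each of compound 3 and compound 4, and repeats of one compound can lie far apart: the several entries of compound 1 in this assay, 6300 nM; 1120 nM (2 entries)

From the compounds shown here alone, how a nitrile, which also holds a triple bond, or an amine would compare on this same carbon remains open. It is also open whether ethynyl in place of ethyl would give a similar step if the rest of the shared core were changed, since only one such pair is shown.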